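The source may hold more compounds than are shown below. What is called first, only, known or untested is meant among the compounds shown, and "the series" means these compounds.

Measured so far:
compound 1 `CN1CCN(Cc2ccc(NC(=O)Nc3ccc4ncnc(Nc5cccc(C(F)(F)F)c5)c4c3)cc2)CC1` gives 2410 nM in a functional assay on A-431 cells (Homo sapiens) for antiproliferative activity, read by MTT assay, with a stated time of 72 h; a higher number here means a weaker inhibitor, a lower number a stronger inhibitor
compound 2 `O=C(Nc1ccc(CN2CCCCC2)cc1)Nc1ccc2ncnc(Nc3cccc(C(F)(F)F)c3)c2c1` gives 1550 nM in this assay
compound 3 `O=C(Nc1ccc(CN2CCCC2)cc1)Nc1ccc2ncnc(Nc3cccc(C(F)(F)F)c3)c2c1` gives 1360 nM in this assay

Compound 3 has the lowest of these three numbers, yet the steps to it, a 1.1-fold lower number from compound 2 to compound 3 (0.06 log units; within the scatter) and a 1.8-fold lower number from compound 1 to compound 3 (0.25 log units; within the scatter), both lie within the scatter, so the three cannot be ranked. Compound 4 `CCN(CC)Cc1ccc(NC(=O)Nc2ccc3ncnc(Nc4cccc(C(F)(F)F)c4)c3c2)cc1` differs from compound 3 in one place: diethylamino in place of pyrrolidin-1-yl on a saturated chain carbon bound to an aromatic carbon. Every measured step swaps the amine on that same saturated chain carbon, and each was small: a 1.6-fold lower number from compound 1 to compound 2 (0.19 log units; within the scatter), a 1.8-fold lower number from compound 1 to compound 3 (0.25 log units; within the scatter) and a 1.1-fold lower number from compound 2 to compound 3 (0.06 log units; within the scatter). A further swap of that amine is therefore expected to give no step beyond the scatter in this assay. The expected step is a 1.0-fold higher number from compound 3 to compound 4 (0.01 log units; within the scatter). Compound 4 is estimated at 1400 nM, with a range from 700 nM to 2800 nM.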

Compound 4, half-maximal inhibitory concentration: 3980 nM
Beside the measured number, compound 4's estimate is 2.8-fold (0.45 log units) below it; measured number outside the range, above it.
By their numbers in this assay, from the lowest: compounds 3, 2, 1 and 4 (each within the scatter of the next, the first and the last beyond it).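

At this saturated chain carbon, the amine swap can matter after all: replacing pyrrolidin-1-yl with diethylamino, which has the same heavy-atom count but no ring, gives a step beyond the scatter in this assay (a 2.9-fold higher number from compound 3 to compound 4 (0.47 log units; beyond the scatter)), and replacing piperidin-1-yl does too (a 2.6-fold higher number from compound 2 to compound 4 (0.41 log units; beyond the scatter)). The ring-to-open-chain pattern does not hold for compound 1, whose step stays within the scatter (a 1.7-fold higher number from compound 1 to compound 4 (0.22 log units; within the scatter)). No available evidence explains this difference. On these data alone, with diethylamino as the only open-chain amine, it remains open whether dimethylamino or morpholin-4-yl would behave like it or like the ring amines.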